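The source may hold more compounds than are shown below. What is called first, only, known or untested is meant among the compounds shown, and "the series" means these compounds.

The compounds here share one core, seen in compound 1 `NC(N)=NC(=O)c1nc(Cl)c(Nc2ccccc2)nc1N`, which in an assay for inhibition of acid-sensing ion channel 3 (Homo sapiens), read by patch clamp, tested at 1 uM (on this read-out higher numbers stand for more inhibition at the one concentration tested (going by the name of the read-out) and lower numbers for less inhibition), gives 44%. Compound 2 `NC(N)=NC(=O)c1nc(Cl)c(O)nc1N` carries a hydroxy group where compound 1 carries a phenylamino group, but for compound 2 in this assay the reported result is "not determined" (no result reported), so compound 2 stands without a number of its own and cannot be placed against compound 1.

The step under study leads from compound 2 to compound 3 `NC(N)=NC(=O)c1nc(Cl)c(Sc2ccccc2)nc1N`, and the change is this: phenylsulfanyl in place of hydroxy on an aromatic carbon. For the measured compounds named here, since compound 2 has no value in this assay, no size or direction of the step can be read from measured numbers, and the only anchor is compound 1, whose phenylamino group resembles the phenylsulfanyl group now entering.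

On that basis compound 3 is expected in this assay to sit near compound 1, because compound 1 gives 44%; the estimate for compound 3 is 45%, with a range from 20% to 70%, and the measured value will show whether this holds.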

Compound 3, a percentage reported as inhibition, at one concentration (the size of the read-out at that concentration, not a potency): 11%
Compound 3: middle estimate off by 34 percentage points, on the high side, outside the stated range (below it).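

In this assay, putting phenylsulfanyl in place of anilino on this aromatic carbon gives a number 33 percentage points lower from compound 1 to compound 3 (beyond the scatter), so these two groups are not interchangeable here, even though each brings a six-membered aromatic ring of carbon to the same place on the shared core. The presence of that ring alone therefore does not set the inhibition at this position: within this pair, the outcome also depends on whether a nitrogen or a sulfur joins the ring to the core. No measurement at hand explains the difference between the two groups.

On these data alone, the step between compound 2 and compound 3 cannot be read, as compound 2 has no number of its own, so the effect of replacing hydroxy remains unknown. Also open, as far as these compounds go, is how a phenoxy group, which would join the same ring through oxygen, or a small methylamino group, which would keep the joining nitrogen without the ring, would compare with compound 1 and compound 3 on this carbon.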